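Chloro to Bromo on the Shared Core

The source may hold more compounds than are shown below. What is called first, only, known or untested is meant among the compounds shown, and "the series" means these compounds.

Compound 1, `CC(c1ccc(-c2ccccc2)c(F)c1)c1nnc2n1N=C(c1ccc(Cl)cc1Cl)CS2`, gives 5400 nM in a functional assay on FOCUS cells (Homo sapiens) for inhibition, read by sulforhodamine B assay, with a stated time of 72 h; a higher number here means a weaker inhibitor, a lower number a stronger inhibitor.
Compound 2, `COc1ccc(C2=Nn3c(nnc3C(C)c3ccc(-c4ccccc4)c(F)c3)SC2)cc1`, gives 4400 nM.
Compound 3, `CC(c1ccc(-c2ccccc2)c(F)c1)c1nnc2n1N=C(c1ccc(Cl)cc1)CS2`, gives 5000 nM.

Compound 3 holds the second highest of the three numbers; its nearest neighbour is compound 1 and its furthest is compound 2, and both gaps lie within the scatter. Compound 4, `CC(c1ccc(-c2ccccc2)c(F)c1)c1nnc2n1N=C(c1ccc(Br)cc1)CS2`, differs from compound 3 by one change: bromo in place of chloro on an aromatic carbon. The steps that touch this aromatic carbon, a 1.1-fold lower number from compound 1 to compound 3 (0.03 log units; within the scatter) and a 1.1-fold higher number from compound 2 to compound 3 (0.06 log units; within the scatter), were both within the scatter, so a halogen swap there has so far moved nothing. The expected step in this assay is therefore no change at the digits printed from compound 3 to compound 4 (within the scatter), with no direction beyond the scatter. Compound 4 is estimated at 5000 nM, with a range from 2500 nM to 10000 nM.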

Compound 4, half-maximal inhibitory concentration: 8500 nM
Beside the measured number, compound 4's estimate is 1.7-fold (0.23 log units) below it; low and high end bracket the measured number.
By their numbers in this assay, from the lowest: compounds 2, 3, 1 and 4 (each within the scatter of the next).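

With bromo on this aromatic carbon, the step stays inside the scatter in this assay: a 1.7-fold higher number from compound 3 to compound 4 (0.23 log units; within the scatter). The comparisons with the other two aromatic groups also stay inside it, at a 1.9-fold higher number from compound 2 to compound 4 (0.29 log units; within the scatter) and a 1.6-fold higher number from compound 1 to compound 4 (0.20 log units; within the scatter), so the four groups seen here are not told apart, although the first of these two steps lies close to the edge of the scatter. Nothing measured here offers a reason for the sizes of these steps. Going by these compounds, whether an amine or a carboxylic acid on this aromatic carbon would give a step beyond the scatter remains open.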